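The source may hold more compounds than are shown below. What is called first, only, known or untested is meant among the compounds shown, and "the series" means these compounds.

Compound 1, `CC(=O)N1N=C(c2ccc(C)cc2)CC1c1cn(-c2ccccc2)nc1-c1ccc(Cl)c(Cl)c1`: in a functional assay on the whole organism (strain Wistar) for inhibition, with Rattus norvegicus as the target, read by paw edema, with stated times of 30 min and 60 min, at a dose of 50 mg/kg by the oral route (on this read-out higher numbers stand for more inhibition at the one dose given (going by the name of the read-out) and lower numbers for less inhibition), compound 1 gives 59.5%.
Compound 2, `CC(=O)N1N=C(c2ccc(Cl)cc2)CC1c1cn(-c2ccccc2)nc1-c1ccc(Cl)c(Cl)c1`: in this assay compound 2 gives 57.3%.
Compound 3, `CCC(=O)N1N=C(c2ccc(Cl)cc2)CC1c1cn(-c2ccccc2)nc1-c1ccc(Cl)c(Cl)c1`: in this assay compound 3 gives 61.1%.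

Among these three numbers compound 1 stands second; its nearest neighbour is compound 3 and its furthest is compound 2, and both gaps lie within the usual scatter, so the three compounds cannot be told apart on this read-out.

Compound 4, `Cc1ccc(C2=NN(c3ccccc3)C(c3cn(-c4ccccc4)nc3-c3ccc(Cl)c(Cl)c3)C2)cc1`, differs from compound 1 in one place: phenyl in place of acetyl on an amine nitrogen in a ring. Two measured steps are available for comparison. Exchanging the group on the aromatic ring gave a number 2.2 percentage points lower from compound 1 to compound 2 (within the scatter), and altering the acyl group at the ring nitrogen gave a number 3.8 percentage points higher from compound 2 to compound 3 (within the scatter). Among the measured compounds shown here, neither of them replaces the acetyl group with a ring, so there is no direct precedent for the present change. The closest hint is that the one alteration made at the acyl group moved the number only within scatter. On this basis the step from compound 1 to compound 4 is expected to stay within scatter, as a number 1.5 percentage points lower from compound 1 to compound 4 (within the scatter), though with more uncertainty than the measured steps carry. Compound 4 is therefore estimated at 58%, within a range from 44% to 72%.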

Compound 4, a percentage reported as inhibition, in the whole organism at one dose (the size of the read-out at that dose, not a potency): 58.8%
For compound 4 the middle estimate is 0.8 percentage points below the measured one; low and high end bracket the measured number.
By their numbers in this assay, from the lowest: compounds 2, 4, 1 and 3 (each within the scatter of the next).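

Among the compounds shown here, putting phenyl in place of acetyl on the amine nitrogen in the ring gave a number 0.7 percentage points lower from compound 1 to compound 4 (within the scatter) in this assay, even though this swap is much larger than the one earlier change at this nitrogen, which only added a methyl to the acyl chain. The carbonyl, with its hydrogen-bond acceptor, leaves, and a six-membered aromatic ring of carbon only enters, so on this read-out at this one dose an acyl group at this nitrogen is not required for a number of this size. Nothing measured here bears on why the two groups read alike.

The compounds shown leave open whether other groups at this nitrogen, such as a plain ethyl chain, a longer acyl chain like butanoyl, or a phenyl ring carrying a carboxylic acid, would also stay within the scatter. A read-out at a single dose also gives no potency, so compound 1 and compound 4 could still separate at other doses.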